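A few compounds are considered here, and "the series" means these few. Any claim that something is new, unique, unknown or untested is made for them only; others in the source may bear on it.

Values in a functional assay on A549 cells (Homo sapiens) for inhibition, read by MTT assay, with a stated time of 48 h (on this read-out higher numbers stand for weaker inhibition and lower numbers for stronger inhibition), for the series so far:

compound 1 `COc1cc(NC(=O)Nc2ccccn2)cc(-c2cccnc2)c1OC`: 13500 nM
compound 2 `O=C(Nc1ccccn1)Nc1cc(-c2cncnc2)ccc1OC(F)(F)F`: 15200 nM
compound 3 `O=C(Nc1ccncc1)Nc1cc(-c2cccnc2)cc(C(F)(F)F)c1`: > 300000 nM (a limit of the assay, not a number)
compound 4 `COc1ccc(-c2cc(NC(=O)Nc3ccncc3)cc(C(F)(F)F)c2)cn1`: not yet measured

Compound 3 has only a limit in this assay, namely > 300000 nM and no number. Compound 1 reads 13500 nM and compound 2 reads 15200 nM, two values within the usual scatter of each other.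

The change to compound 4 is methoxy in place of hydrogen on an aromatic carbon of a six-membered aromatic ring with 1 nitrogen, next to the ring nitrogen, para to a large group. Pyridin-3-yl thus becomes 6-methoxypyridin-3-yl.

For the measured compounds named here, no measured pair covers this change, so the expectation is loose. Compound 1 at 13500 nM shows that a measured number is reachable in this series. A large step toward stronger inhibition is expected, with a real chance that the reading stays at the limit. The expected step is an at least 7.5-fold lower number from compound 3 to compound 4 (0.87 log units; beyond the scatter) in this assay, wide in its uncertainty. For compound 4 the estimate is 40000 nM, with an expected range from 6000 nM to 250000 nM.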

Compound 4, half-maximal inhibitory concentration: 276000 nM
For compound 4 the middle estimate is 6.9-fold (0.84 log units) below the measured one, outside the stated range (above it).
By their numbers in this assay, from the lowest: compounds 1 and 2 (each within the scatter of the next); then compound 4. At a limit, above all of these: compound 3.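

Compound 3 carries the limit > 300000 nM and no number (this assay). With methoxy in place of hydrogen on an aromatic carbon, next to the ring nitrogen, compound 4 gives 276000 nM as a number and not a limit, so 6-methoxypyridin-3-yl yields a reading in this assay where pyridin-3-yl yields none. The pair supports only an at least 1.0-fold lower number from compound 3 to compound 4 (0.03 log units; that floor lies within the scatter) as a floor, so a real gain from methoxy at this position is not established, one end of the pair being a limit: the limit of > 300000 nM in this assay, at which 1 of the 4 values shown sits.

Still open, as far as these compounds go, is whether an amine or a longer chain such as ethoxy at the same position would give a lower number than compound 4. Also open, from the compounds shown here alone, is whether methoxy at this position would shift the reading of compound 1, 13500 nM in this assay, on its own core.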